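Putting a piperazine back on compound 2

This account rests on a few compounds, and the source may have more. Where it says the series, first, only, none or still open, it means among the compounds named here.

In a functional assay on LNCaP cells (Homo sapiens) for antiproliferative activity, read by MTT assay, with a stated time of 96 h (a higher number here means a weaker inhibitor, a lower number a stronger inhibitor), compound 2 `FC(F)(F)Oc1cccc(Nc2nnnc3ccc(N4CCCC4)nc23)c1` reads > 100000 nM, which is a limit and not a number. Compound 3 `CC(C)(C)OC(=O)N1CCC(CNc2ccc3nnnc(Nc4cccc(OC(F)(F)F)c4)c3n2)CC1` reads > 100000 nM, also a limit. Both sit at the limit of > 100000 nM in this assay, at which 2 of the 3 values shown sit. Only compound 1 `CCN1CCN(c2ccc3nnnc(Nc4cccc(OC(F)(F)F)c4)c3n2)CC1` gives a true number, 14300 nM.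

Compound 4 `CC(C)N1CCN(c2ccc3nnnc(Nc4cccc(OC(F)(F)F)c4)c3n2)CC1` has 4-isopropylpiperazin-1-yl in place of pyrrolidin-1-yl on an aromatic carbon, next to the ring nitrogen: 4-isopropylpiperazin-1-yl in place of pyrrolidin-1-yl on an aromatic carbon. Going by the values given here, the one measured step that bears on this runs the opposite way, swapping 4-ethylpiperazin-1-yl for pyrrolidin-1-yl: an at least 6.9-fold higher number from compound 1 to compound 2 (0.84 log units; beyond the scatter). Reversing that kind of swap should lower the number in this assay, so the expected size is an at least 6.6-fold lower number from compound 2 to compound 4 (0.82 log units; beyond the scatter). Compound 4 is estimated at 15000 nM, with an expected range of 5000 nM to 50000 nM.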

Compound 4, half-maximal inhibitory concentration: 10700 nM
Estimate against measurement, compound 4: 1.4-fold (0.15 log units) above; the range from low to high includes it.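

In this assay, both piperazines on this aromatic carbon, next to the ring nitrogen, give a true number where pyrrolidin-1-yl does not: an at least 9.3-fold lower number from compound 2 to compound 4 (0.97 log units; beyond the scatter). The size of that step is only a lower bound, since the value of compound 2 is a limit: the limit of > 100000 nM in this assay, at which 2 of the 4 values shown sit. Swapping 4-ethylpiperazin-1-yl for 4-isopropylpiperazin-1-yl makes no clear difference: a 1.3-fold lower number from compound 1 to compound 4 (0.13 log units; within the scatter).

On these data alone, whether the gain comes from the second ring nitrogen or from the larger group stays open. A morpholine or a piperidine at this position would help separate the two.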